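Lengthening the Amino Chain of Compound 2

The compounds below may be only part of what the source reports. "The series", "measured", "known", "first", "only" and "open" are said of these compounds alone.

Compound 1 `Cc1ccccc1C(=O)Nc1ccc(S(=O)(=O)NC2CCN(C(=O)CO)CC2)c2ccccc12` and compound 2 `Cc1ccccc1C(=O)Nc1ccc(S(=O)(=O)NC2CCN(C(=O)CCN)CC2)c2ccccc12` share one core and differ in one place. In an assay on L1.2 cells for binding affinity to C-C chemokine receptor type 8 (Homo sapiens) (on this read-out lower numbers stand for stronger inhibition and higher numbers for weaker inhibition), compound 1 gives 5.4 nM, while compound 2 gives 11.3 nM, so compound 2 stands with the higher of the two numbers; the step of a 2.1-fold higher number from compound 1 to compound 2 (0.32 log units; beyond the scatter) is modest, though beyond the scatter. Compound 3 `Cc1ccccc1C(=O)Nc1ccc(S(=O)(=O)NC2CCN(C(=O)CCCN)CC2)c2ccccc12` is the next variation: aminomethyl in place of amino on a saturated chain carbon, two bonds along the chain from a carbonyl carbon, so the amino group moves one carbon further out along the chain. Among the measured compounds shown here, the only measured step that bears on this is a 2.1-fold higher number from compound 1 to compound 2 (0.32 log units; beyond the scatter), and it swapped a different group, so it gives only a loose guide. Such a small extension of a flexible chain is expected to shift this assay little, if at all beyond the scatter. Compound 3 is therefore estimated at 12 nM, with a likely range from 5 nM to 30 nM, meaning an expected step of a 1.1-fold higher number from compound 2 to compound 3 (0.03 log units; within the scatter).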

Compound 3, inhibition constant: 1.6 nM
Compound 3: middle estimate off by 7.5-fold (0.88 log units), on the high side, and the stated range ends above it.
By their numbers in this assay, from the lowest: compound 3; then compound 1; then compound 2.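

In this assay, the change of aminomethyl in place of amino gives a 7.1-fold lower number from compound 2 to compound 3 (0.85 log units; beyond the scatter), so this position is sensitive to the length of the chain and not only to the group at its end. Against the hydroxy compound, the outcome depends on that length: the shorter amino chain gave a 2.1-fold higher number from compound 1 to compound 2 (0.32 log units; beyond the scatter), whereas the longer one gives a 3.4-fold lower number from compound 1 to compound 3 (0.53 log units; beyond the scatter), an opposite direction that compound 2 alone could not reveal. Nothing measured here explains this difference.

The compounds shown leave open whether a still longer chain ending in an amine, such as 4-aminobutyl, would lower the number further or raise it again. They also leave open whether the amine itself matters at this chain length, which a chain ending in a hydroxy group or a carboxylic acid would test.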